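3-Methylthiophen-2-yl in place of 4-(dimethylamino)phenyl

The source may report more compounds than this note shows. Statements on the series, on what has been measured and on what is new or still open speak of the compounds shown alone.

- compound 1 `COc1ccccc1/C=C(/SCc1ccc(F)cc1)C(=O)c1ccc(Cl)cc1` gives 10000 nM
- compound 2 `CN(C)c1ccc(/C=C(/SCc2ccc(F)cc2)C(=O)c2ccc(Cl)cc2)cc1` gives 50000 nM

In a functional assay on DU-145 cells (Homo sapiens) for inhibition, read by trypan blue exclusion, with a stated time of 96 h (on this read-out higher numbers stand for weaker inhibition of growth and lower numbers for stronger inhibition of growth), compound 2 holds the higher of the two numbers, and so shows the weaker growth inhibition. Compound 3 `Cc1ccsc1/C=C(/SCc1ccc(F)cc1)C(=O)c1ccc(Cl)cc1` brings a new group to the same place, 3-methylthiophen-2-yl in place of 4-(dimethylamino)phenyl on a double-bonded chain carbon bound to a double-bonded chain carbon is the change. Among the measured compounds shown here, only one measured step bears on this place, a 5.0-fold higher number from compound 1 to compound 2 (0.70 log units; beyond the scatter), which is modest, and no measured compound carries this new group. A modest fall is therefore expected, and the estimated move is a 3.3-fold lower number from compound 2 to compound 3 (0.52 log units; beyond the scatter), though with wide uncertainty. For compound 3 the estimate is 15000 nM with an expected range from 4000 nM to 50000 nM in this test.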

Compound 3, concentration for 50% growth inhibition: 50000 nM
Beside the measured number, compound 3's estimate is 3.3-fold (0.52 log units) below it; low and high end bracket the measured number.
By their numbers in this assay, from the lowest: compound 1; then compounds 2 and 3 (each within the scatter of the next).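

In this assay, 3-methylthiophen-2-yl in place of 4-(dimethylamino)phenyl gives no change at the digits printed from compound 2 to compound 3 (within the scatter), so a five-membered aromatic ring with one hetero atom and a six-membered aromatic ring of carbon only read alike at this place. Against 2-methoxyphenyl, the same new group gives a 5.0-fold higher number from compound 1 to compound 3 (0.70 log units; beyond the scatter), which leaves compound 1 with the lowest number of the three. From the compounds shown here alone, whether a carboxylic acid or a morpholine at this place would bring the number under that of compound 1 stays open. No measurement at hand offers a reason for these results.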